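Two methyl groups enter an anilide that sits at a limit

A few compounds are considered here, and "the series" means these few. Any claim that something is new, unique, unknown or untested is made for them only; others in the source may bear on it.

Measured so far:
compound 1, `CC(C)c1cccc(C(C)C)c1OC(=O)CC(=O)Nc1ccccc1`: > 5000 nM
compound 2, `CCCCCCCCOC(=O)CC(=O)Nc1c(C(C)C)cccc1C(C)C`: 260 nM

In an assay on microsomes from intestine for inhibition of acyl-CoA:cholesterol acyltransferase (Oryctolagus cuniculus) (on this read-out higher numbers stand for weaker inhibition and lower numbers for stronger inhibition), compound 1 gives > 5000 nM, which is a limit of the assay rather than a number, so compound 1 stands at the limit of > 5000 nM in this assay, at which 1 of the 2 values shown sits. For the measured compounds named here, compound 2 gives 260 nM in this assay, but it differs from compound 1 in more than one place, so no single step joins them. Compound 3, `Cc1cccc(C)c1NC(=O)CC(=O)Oc1c(C(C)C)cccc1C(C)C`, changes compound 1 in one place: 2,6-dimethylphenyl in place of phenyl on an amide-type nitrogen. For compound 3 the step of an at least 5.0-fold lower number from compound 1 to compound 3 (0.69 log units; beyond the scatter) is expected to go toward stronger inhibition and beyond the scatter, though a limit might again be all that is read. Compound 3 is estimated at 1000 nM, between 200 nM and 5000 nM.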

Compound 3, half-maximal inhibitory concentration: 210 nM
The estimate for compound 3 lay 4.8-fold (0.68 log units) above the measured number; measured number inside the range.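

In this assay, 2,6-dimethylphenyl in place of phenyl on the amide-type nitrogen gives an at least 23-fold lower number from compound 1 to compound 3 (1.37 log units; beyond the scatter), so this position, silent so far, responds strongly to a small addition of carbon. Compound 1 gives > 5000 nM, a limit and not a number, so the full size of this step cannot be read: the limit of > 5000 nM in this assay, at which 1 of the 3 values shown sits.

Going by these compounds, whether a single methyl group would be enough stays open. So does whether 2,6-diisopropylphenyl or 2,6-dichlorophenyl on this nitrogen would go further than the two methyl groups.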